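Amide aryl variation on a shared core: toward compound 4

A few compounds are considered here, and "the series" means these few. Any claim that something is new, unique, unknown or untested is made for them only; others in the source may bear on it.

Compound 1 `CN(C)C(=O)c1cc2cnc(Nc3ccc(NC(=O)C4(C(=O)Nc5ccc(F)cc5)CC4)cc3)nc2n1C1CCCC1` carries a 4-fluorophenyl on the amide-type nitrogen. In a functional assay on A549 cells (Homo sapiens) for inhibition, read by CCK-8 assay, with a stated time of 72 h, tested at 1 uM (on this read-out lower numbers stand for less inhibition of growth and higher numbers for more inhibition of growth at the one concentration tested), compound 1 gives 86.6%, the highest of the three numbers in hand. Compound 2 `COC(=O)c1ccc(NC(=O)C2(C(=O)Nc3ccc(Nc4ncc5cc(C(=O)N(C)C)n(C6CCCC6)c5n4)cc3)CC2)cc1` gives 77.1%, and the step of a number 9.5 percentage points lower from compound 1 to compound 2 (within the scatter) lies within the scatter. Compound 3 `CN(C)C(=O)c1cc2cnc(Nc3ccc(NC(=O)C4(C(=O)Nc5cccc(C(F)(F)F)c5)CC4)cc3)nc2n1C1CCCC1` gives 15.7%; the step of a number 70.9 percentage points lower from compound 1 to compound 3 (beyond the scatter) is large, as is a number 61.4 percentage points lower from compound 2 to compound 3 (beyond the scatter).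

Compound 4 `COc1cccc(NC(=O)C2(C(=O)Nc3ccc(Nc4ncc5cc(C(=O)N(C)C)n(C6CCCC6)c5n4)cc3)CC2)c1` differs from compound 1 by 3-methoxyphenyl in place of 4-fluorophenyl on an amide-type nitrogen. For the measured compounds named here, the only step among the measured compounds that also exchanges the aryl on the amide-type nitrogen for a 3-substituted phenyl is a number 70.9 percentage points lower from compound 1 to compound 3 (beyond the scatter), which was large and downward; the exchange in a number 9.5 percentage points lower from compound 1 to compound 2 (within the scatter) kept the aryl pattern of compound 1 and cost nothing beyond the scatter. With one such precedent only, a downward step in this assay is expected for compound 4, but its size is uncertain. The estimate for compound 4 is 45%, range 10% to 80%, an expected step of a number 41.6 percentage points lower from compound 1 to compound 4 (beyond the scatter).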

Compound 4, percent growth inhibition at one concentration: 77.2%
Compound 4: middle estimate off by 32.2 percentage points, on the low side; measured number inside the range.
By their numbers in this assay, from the lowest: compound 3; then compounds 2, 4 and 1 (each within the scatter of the next).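

In this assay the exchange of 4-fluorophenyl for 3-methoxyphenyl on the amide-type nitrogen gives a number 9.4 percentage points lower from compound 1 to compound 4 (within the scatter), so a 3-substituted phenyl at this position does not by itself bring the loss seen with compound 3. With methoxy in place of trifluoromethyl on an aromatic carbon the series shows a number 61.5 percentage points higher from compound 3 to compound 4 (beyond the scatter), which ties the low number among these compounds to the 3-(trifluoromethyl)phenyl group, the only aryl here with a low number. The step of a number 0.1 percentage points higher from compound 2 to compound 4 (within the scatter) leaves the 3-methoxyphenyl and 4-(methoxycarbonyl)phenyl groups indistinguishable on this read-out.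

On these data alone, whether an amine or a carboxylic acid in place of the methoxy of compound 4 would keep the number stays open. Nothing at hand explains the gap between the methoxy and trifluoromethyl compounds.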